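A few compounds are considered here, and "the series" means these few. Any claim that something is new, unique, unknown or untested is made for them only; others in the source may bear on it.

Measured compounds:
compound 1 `CC(=O)Nc1ccn([C@@H]2CO[C@H](CO)O2)c(=O)n1`: in a functional assay on SW1573 cells (Homo sapiens) for cytotoxicity, read by sulforhodamine B assay, with a stated time of 72 h (on this read-out lower numbers stand for stronger inhibition and higher numbers for weaker inhibition), compound 1 gives 10700 nM
compound 2 `CCCC(=O)Nc1ccn([C@@H]2CO[C@H](CO)O2)c(=O)n1`: in this assay compound 2 gives 8070 nM

Among the measured compounds shown here, compound 2 carries the lower of the two numbers so far, its nearest neighbour being compound 1, but the step of a 1.3-fold lower number from compound 1 to compound 2 (0.12 log units; within the scatter) lies within the scatter, so the two compounds cannot be ranked against each other on these data.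

Compound 3 `CCCCC(=O)Nc1ccn([C@@H]2CO[C@H](CO)O2)c(=O)n1` is the next member of the acyl chain series. Its difference from compound 2 is methyl in place of hydrogen on a saturated chain carbon, three bonds along the chain from a carbonyl carbon. For the measured compounds named here, the only measured step that bears on this change is the chain extension a 1.3-fold lower number from compound 1 to compound 2 (0.12 log units; within the scatter), which stayed within the scatter. With a single comparable step of that size, no movement beyond the scatter is expected in this assay for compound 3; the expected step is a 1.2-fold lower number from compound 2 to compound 3 (0.06 log units; within the scatter). Compound 3 is therefore estimated at 7000 nM, with a range of 3500 nM to 14000 nM.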

Compound 3, half-maximal inhibitory concentration: 9130 nM
The estimate for compound 3 lay 1.3-fold (0.12 log units) below the measured number, and the stated range covers the measured number.
By their numbers in this assay, from the lowest: compounds 2, 3 and 1 (each within the scatter of the next).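

In this assay, methyl in place of hydrogen on a saturated chain carbon, three bonds along the chain from a carbonyl carbon, gives a 1.1-fold higher number from compound 2 to compound 3 (0.05 log units; within the scatter) and thus adds a second chain extension that stays within the scatter. Among the compounds shown here, the whole extension of the chain gives a 1.2-fold lower number from compound 1 to compound 3 (0.07 log units; within the scatter), so even the widest change in this set is within the scatter, which the single earlier step could not show. Across compound 1, compound 2 and compound 3 the chain length therefore separates nothing on this read-out, and no independent data bear on this result.

From the compounds shown here alone, whether a much longer chain, such as octyl or dodecyl, would move the number beyond the scatter remains open. Going by these compounds, it is equally open whether a chain end carrying an amine or a carboxylic acid, or a phenyl group in place of the chain, would do so.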